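The source may hold more compounds than are shown below. What is called first, only, known or untested is meant among the compounds shown, and "the series" means these compounds.

Measured in an ADME assay on the whole organism (Rattus norvegicus) for metabolic stability, at a dose of 0.5 mg/kg by the intravenous route; on this read-out lower numbers stand for a shorter-lived compound and higher numbers for a longer-lived compound:
Compound 1 `COc1cc(OCc2cccc(-c3ccc(OC)nc3)c2)c2cc(-c3cn4nc(OC)sc4n3)oc2c1`: 45 h
Compound 2 `COc1cc(OCc2cccc(-c3cnc(OC)nc3)c2)c2cc(-c3cn4nc(OC)sc4n3)oc2c1`: 40 h
Compound 3 `COc1cc(OCc2csc(-c3ccccc3)n2)c2cc(-c3cn4nc(OC)sc4n3)oc2c1`: 52 h

Compound 1 stands level with compound 2 and compound 3, since all three values lie within the scatter of each other. Compound 4 `COc1ccc(-c2cccc(COc3cc(OC)cc4oc(-c5cn6nc(OC)sc6n5)cc34)c2)nc1` differs from compound 1 in one place: 5-methoxypyridin-2-yl in place of 6-methoxypyridin-3-yl on an aromatic carbon. Here 5-methoxypyridin-2-yl takes the place of 6-methoxypyridin-3-yl on an aromatic carbon. Within the data shown here, one measured step bears on this place, a change to 2-methoxypyrimidin-5-yl: a 1.1-fold lower number from compound 1 to compound 2 (0.05 log units; within the scatter). Among the measured compounds shown here, no measurement covers the exact swap, so that small step is the only guide and no direction is favoured. The expected step is no change at the digits printed from compound 1 to compound 4 (within the scatter), with nothing beyond the scatter foreseen. Compound 4 is estimated at 45 h, with an expected range from 25 h to 80 h.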

Compound 4, half-life: 110 h
Beside the measured number, compound 4's estimate is 2.4-fold (0.39 log units) below it, outside the stated range (above it).
By their numbers in this assay, from the lowest: compounds 2, 1 and 3 (each within the scatter of the next); then compound 4.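

In this assay, placing 5-methoxypyridin-2-yl at this position gives a 2.4-fold higher number from compound 1 to compound 4 (0.39 log units; beyond the scatter), and the comparison with the pyrimidine gives a 2.8-fold higher number from compound 2 to compound 4 (0.44 log units; beyond the scatter). Among these compounds, the earlier swap at this place had stayed within the scatter, so this is the first sign that the number responds to the group here, even though the leaving and entering groups have the same atoms and counts. Nothing available explains the rise.

The compounds shown leave open how an amine, a carboxylic acid or a longer chain in place of the methoxy group would fare at this position. They also leave open whether 5-methoxypyridin-2-yl would give a similar step on another core.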